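A few compounds are considered here, and "the series" means these few. Any claim that something is new, unique, unknown or untested is made for them only; others in the source may bear on it.

In an ADME assay on cells (Peritoneal macrophage cell, Mus musculus) for cytotoxicity, read by fluorescence and resazurin assay, with a stated time of 3 days (on this read-out higher numbers stand for lower toxicity in this test and lower numbers for higher toxicity in this test), compound 1, `O=C(Nc1[nH]nc(-c2ccccn2)c1C1CC1)c1ccccc1F`, gives > 64000 nM, which is a limit of the assay and not a number. Compound 2, `N#Cc1ccc(OC2CCN(C(=O)Nc3cc(-c4ccccn4)n[nH]3)CC2)cc1`, gives > 64000 nM, and this too is a limit. Compound 2 therefore stands at the limit of > 64000 nM in this assay, at which 2 of the 2 values shown sit, and no exact figure is available for it. Within the data shown here, no measured step connects the two compounds.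

Compound 3, `O=C(Nc1cc(-c2ccccn2)n[nH]1)N1CCC(Oc2ccccn2)CC1`, has not yet been measured. It differs from compound 2 in one place: pyridin-2-yl in place of 4-cyanophenyl on an oxygen on a saturated carbon. Put simply, pyridin-2-yl stands in place of 4-cyanophenyl on an oxygen on a saturated carbon, and the rest of the structure is unchanged.

The expectation for compound 3 rests on compound 2, whose reading of > 64000 nM is a limit. The expected step, an at least 1.0-fold lower number from compound 2 to compound 3 (0.02 log units; that floor lies within the scatter), is none beyond the usual scatter, and no direction is favoured with any confidence. A report at the same limit is the most likely outcome in this assay. The estimated value for compound 3 is 60000 nM, with an expected range from 25000 nM to 64000 nM.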

Compound 3, half-maximal cytotoxic concentration: > 64000 nM
Compound 3: no number, only a limit; the forecaster's own chance of this, stated with the estimate: 80%; at least 1.0-fold (0.02 log units) between middle value and limit.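

In this assay compound 3 gives > 64000 nM as a limit and not a number. Among these compounds, compound 2 also stands at a limit, so no step from compound 2 to compound 3 can be read. The compounds shown leave open whether pyridin-2-yl in place of 4-cyanophenyl changes the half-maximal cytotoxic concentration at all, and where the true values of compound 2 and compound 3 lie.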